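The source may hold more compounds than are shown below. What is called first, only, known or untested is meant among the compounds shown, and "the series" means these compounds.

Measured so far in an ADME assay on a cell-free system (plasma, Mus musculus) for metabolic stability, tested at 5 uM; a higher number here means that the compound lasts longer, a lower number that the compound disappears faster:
Compound 1 `CNS(=O)(=O)c1cc(C(=O)O)ccc1NCCCCCCCC(F)(F)F`: > 2 h
Compound 2 `O=C(O)c1ccc(NCCCCCCCC(F)(F)F)c(S(=O)(=O)N2CCCC2)c1`: > 2 h

Compound 2 gives > 2 h, which is a limit of this assay and not a number. Compound 1 gives > 2 h, and this too is a limit. Neither compound therefore has an exact half-life, and no order can be read between them.

The next compound is compound 3 `O=C(O)c1ccc(NCCCCCCCC(F)(F)F)c(S(=O)(=O)N2CCCCC2)c1`, which carries piperidin-1-yl in place of pyrrolidin-1-yl on a sulfonyl sulfur. The five-membered non-aromatic ring is thus replaced by a six-membered one, and the rest of the molecule stays the same.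

Going by the values given here, only one measured step bears on this change, because it falls on the same sulfonyl sulfur: a step that the two limits leave unreadable from compound 1 to compound 2. It gives no size to carry over. Compound 3 is expected to show no step beyond the scatter in this assay, in either direction, because of the limit of > 2 h in this assay, at which 2 of the 2 values shown sit, compound 2 among them. The expected change is a step that the limit leaves unreadable from compound 2 to compound 3.

Compound 3 is estimated at 3 h, with an expected range of 1.5 h to 6 h.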

Compound 3, half-life: > 2 h
Compound 3: no number, only a limit; the forecaster's own chance of this, stated with the estimate: 85%; the middle value is on the limit's open side.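

In this assay compound 3 gives > 2 h, which is a limit and not a number. No new step can be read among compound 1, compound 2 and compound 3. The compounds shown leave open how long each one really lasts, and whether the group on the sulfonyl sulfur makes any difference to that: the limit of > 2 h in this assay, at which 3 of the 3 values shown sit.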